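The source may hold more compounds than are shown below. What is called first, only, known or untested is meant among the compounds shown, and "the series" means these compounds.

Three measured compounds share one core, a pyrazoline carrying a dimethylaminophenyl group and a sulfonyl group on the ring nitrogen. Compound 1 `CN(C)c1ccc(C2CC(c3ccc(-n4cncn4)cc3)=NN2S(C)(=O)=O)cc1` gives 10.8% in a functional assay on HCC1806 cells (Homo sapiens) for inhibition, read by sulforhodamine B assay, tested at 10 uM; on this read-out higher numbers stand for more inhibition at the one concentration tested (going by the name of the read-out) and lower numbers for less inhibition. Compound 2 `Cc1ccc(S(=O)(=O)N2N=C(c3ccc(-n4cncn4)cc3)CC2c2ccc(N(C)C)cc2)cc1` gives 27.7% in this assay; the change from compound 1 to compound 2 is 4-methylphenyl in place of methyl on a sulfonyl sulfur, and its effect is a number 16.9 percentage points higher from compound 1 to compound 2 (beyond the scatter). Compound 3 `CN(C)c1ccc(C2CC(c3ccc(-n4ccnc4)cc3)=NN2S(C)(=O)=O)cc1` gives 11.3% in this assay; it differs from compound 1 in its core by 1H-imidazol-1-yl in place of 1H-1,2,4-triazol-1-yl on an aromatic carbon, and that step is a number 0.5 percentage points higher from compound 1 to compound 3 (within the scatter).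

Compound 4 `Cc1ccc(S(=O)(=O)N2N=C(c3ccc(-n4ccnc4)cc3)CC2c2ccc(N(C)C)cc2)cc1` has not yet been measured. It differs from compound 3 by 4-methylphenyl in place of methyl on a sulfonyl sulfur, the same change that turned compound 1 into compound 2, and it occurs twice among these four compounds. Compound 3 sits where compound 1 sits, as a number 0.5 percentage points higher from compound 1 to compound 3 (within the scatter) shows. The step already seen for this change is a number 16.9 percentage points higher from compound 1 to compound 2 (beyond the scatter). The same change is expected to be about that size again, that is a number 15.7 percentage points higher from compound 3 to compound 4 (beyond the scatter). On that basis compound 4 is estimated to give 27% in this assay, with a range from 12% to 42%.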

Compound 4, a percentage reported as inhibition, at one concentration (the size of the read-out at that concentration, not a potency): 66%
For compound 4 the middle estimate is 39 percentage points below the measured one; the measured number lies above the stated range.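

In this assay, 4-methylphenyl in place of methyl on the sulfonyl sulfur gives a number 54.7 percentage points higher from compound 3 to compound 4 (beyond the scatter), and this step does not match the one seen on the core of compound 1: the same change on two cores in this assay, a number 16.9 percentage points higher (beyond the scatter) from compound 1 to compound 2 and a number 54.7 percentage points higher (beyond the scatter) from compound 3 to compound 4, 37.8 percentage points apart, beyond the scatter of two such steps Read the other way, 1H-imidazol-1-yl in place of 1H-1,2,4-triazol-1-yl leaves no readable difference while methyl sits on the sulfonyl sulfur, yet with 4-methylphenyl there it gives a number 38.3 percentage points higher from compound 2 to compound 4 (beyond the scatter), so this step also depends on its partner: the same change on two cores in this assay, a number 0.5 percentage points higher (within the scatter) from compound 1 to compound 3 and a number 38.3 percentage points higher (beyond the scatter) from compound 2 to compound 4, 37.8 percentage points apart, beyond the scatter of two such steps The two changes therefore do not simply add up across these four compounds, and the size of the sulfonyl step cannot be carried from one core to the other, though one set of four compounds does not show why this happens or whether it extends to other cores.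

The compounds shown leave open whether other groups on the sulfonyl sulfur, such as ethyl, unsubstituted phenyl or 4-chlorophenyl, would follow 4-methylphenyl. They also leave open how compound 4 would rank at concentrations other than the single one tested.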